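The compounds below may be only part of what the source reports. "The series", "measured", "known", "first", "only" and "open" are said of these compounds alone.

Working notes on the series.

Compound 3 `COC(=O)c1ccc(-c2nnn(CC(=O)C(C)Oc3ccc(Oc4ccc(Cl)cc4)cc3)n2)cc1` gives 47 nM in an assay on microsomes from brain for inhibition of Fatty-acid amide hydrolase 1 (Rattus norvegicus), read by fluorescence and HPLC, with a stated time of 60 min; a lower number here means a stronger inhibitor, a higher number a weaker inhibitor. Among the three measured compounds it holds the highest number; its nearest neighbour is compound 2 `COC(=O)c1ccc(-c2nnn(CC(=O)C(C)Oc3ccc(Oc4ccc(F)cc4)cc3)n2)cc1`, which in this assay gives 36 nM, and the furthest is compound 1 `CC(Oc1ccc(-c2ccccc2)cc1)C(=O)Cn1nnc(-c2ccccc2)n1`, which gives 15 nM. Within the data shown here, the only single-point step measured so far, a 1.3-fold higher number from compound 2 to compound 3 (0.12 log units; within the scatter), is small.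

Compound 4 `COC(=O)c1ccc(-c2nnn(CC(=O)C(C)Oc3ccc(-c4ccccc4)cc3)n2)cc1` is the next entry. It differs from compound 3 in one place: phenyl in place of 4-chlorophenoxy on an aromatic carbon. Among the measured compounds shown here, no measured step covers exactly this exchange. Compound 1 carries the same phenyl at that position as compound 4 but lacks the methyl ester on the shared core, so the gap between compound 1 and compound 3 mixes two changes and can only be read as a rough guide. The step from compound 2 to compound 3 does not bear on the exchange in question. What the numbers show is that compound 1, with phenyl in place of the aryloxy group, sits at the low end of the set.

Compound 4 is therefore expected to move toward the number of compound 1, with the step estimated at a 2.4-fold lower number from compound 3 to compound 4 (0.37 log units; beyond the scatter). Compound 4 is estimated at 20 nM in this assay, with a range from 8 nM to 50 nM.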

Compound 4, half-maximal inhibitory concentration: 23 nM
For compound 4 the middle estimate is 1.2-fold (0.06 log units) below the measured one, within the range that was stated.
By their numbers in this assay, from the lowest: compounds 1, 4, 2 and 3 (each within the scatter of the next, the first and the last beyond it).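

The exchange of 4-chlorophenoxy for phenyl, on an aromatic carbon para to a large group, is now measured directly in this assay and gives a 2.0-fold lower number from compound 3 to compound 4 (0.31 log units; beyond the scatter), a modest step that lies beyond the scatter. The matching exchange from the 4-fluorophenoxy group gives a 1.6-fold lower number from compound 2 to compound 4 (0.19 log units; within the scatter), which stays within the scatter, so the effect of replacing an aryloxy group with phenyl is resolved only for the chloro member of this small set. Among these compounds, compound 4 also isolates the methoxycarbonyl group for the first time, and a 1.5-fold higher number from compound 1 to compound 4 (0.19 log units; within the scatter) lies within the scatter, so with phenyl in place, methoxycarbonyl in place of hydrogen on the shared core gives no readable change.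

The compounds shown leave open how an unsubstituted phenoxy group or a benzyloxy group would read at this position in this assay. They also leave open whether a carboxylic acid or a primary amide could stand in place of the methoxycarbonyl group without a step beyond the scatter. Nothing available explains any of these steps.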